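The compounds below may be only part of what the source reports. "The series", "measured", "known", "first", "only" and "open" are said of these compounds alone.

Compound 1 `COc1ccc(C(=O)/C=C/c2cc(OC)c(OC)c(OC)c2)c2c1C=CC(C)(C)O2`: 9700 nM
Compound 2 `COc1ccc(C(=O)/C=C/c2cccc([N+](=O)[O-])c2)c2c1C=CC(C)(C)O2`: 9720 nM
Compound 3 `COc1ccc(C(=O)/C=C/c2cccc(C(F)(F)F)c2)c2c1C=CC(C)(C)O2`: 9330 nM

In a functional assay on SK-OV-3 cells (Homo sapiens) for antiproliferative activity, read by MTT assay, with a stated time of 24 h (a lower number here means a stronger inhibitor, a higher number a weaker inhibitor), compound 2 gives the highest of the three numbers, yet compound 1, its nearest, and compound 3, its furthest, both lie within the scatter of it, so nothing separates the three. Compound 4 `COc1ccc(C(=O)/C=C/c2ccccc2Cl)c2c1C=CC(C)(C)O2` differs from compound 2 in one place: 2-chlorophenyl in place of 3-nitrophenyl on a double-bonded chain carbon bound to a double-bonded chain carbon. Among the measured compounds shown here, the only measured step that bears on this, a 1.0-fold lower number from compound 2 to compound 3 (0.02 log units; within the scatter), swaps one group on the aromatic ring for another and stays within the scatter. For the measured compounds named here, no measured compound carries the 2-chlorophenyl group, so the expectation rests on how flat the numbers are; the step of a 1.0-fold lower number from compound 2 to compound 4 (0.01 log units; within the scatter) is expected to stay within the scatter. Compound 4 is therefore estimated at 9500 nM, with a range of 4000 nM to 22000 nM.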

Compound 4, half-maximal inhibitory concentration: > 10000 nM
Compound 4 gave a limit, no number (the forecaster's own chance of this, stated with the estimate: 10%); middle value at least 1.0-fold (0.02 log units) away from the limit.
By their numbers in this assay, from the lowest: compounds 3, 1 and 2 (each within the scatter of the next). At a limit, above all of these: compound 4.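

In this assay compound 4 gives > 10000 nM, which is a limit and not a number. Putting 2-chlorophenyl in place of 3-nitrophenyl at this place therefore yields only a floor, an at least 1.0-fold higher number from compound 2 to compound 4 (0.01 log units; that floor lies within the scatter), so the true size of the change cannot be read. Compound 4 is the only compound shown whose reading ends at a limit: the limit of > 10000 nM in this assay, at which 1 of the 4 values shown sits.

As far as these compounds go, how far compound 4 really lies from compound 2 remains open. So does how an aromatic ring carrying an amine or a carboxylic acid at this place would read in this assay.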